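Aryl variation at the hydrazone carbon: working notes

The source may report more compounds than this note shows. Statements on the series, on what has been measured and on what is new or still open speak of the compounds shown alone.

Measured so far, all in a functional assay on A549 cells (Homo sapiens) for cytotoxicity, read by MTT assay, with a stated time of 72 h; on this read-out higher numbers stand for weaker inhibition and lower numbers for stronger inhibition:
compound 1 `CN(C)CCn1cnnc1-c1cc(Oc2ccc(NC(=O)N/N=C/c3c(Cl)cccc3Cl)cc2F)ccn1` gives 1410 nM;
compound 2 `COc1ccc(OC)c(/C=N/NC(=O)Nc2ccc(Oc3ccnc(-c4nncn4CCN(C)C)c3)c(F)c2)c1` gives 1950 nM;
compound 3 `CN(C)CCn1cnnc1-c1cc(Oc2ccc(NC(=O)N/N=C/c3ccccc3O[N+](=O)[O-])cc2F)ccn1` gives 1200 nM.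

Compound 3 holds the lowest of the three numbers, but the steps separating it from the others are small: a 1.2-fold lower number from compound 1 to compound 3 (0.07 log units; within the scatter) and a 1.6-fold lower number from compound 2 to compound 3 (0.21 log units; within the scatter). The remaining pair, a 1.4-fold higher number from compound 1 to compound 2 (0.14 log units; within the scatter), is equally flat. The three aryl groups on the carbon with a double bond to nitrogen therefore cannot be told apart on these data.

Compound 4 `CN(C)CCn1cnnc1-c1cc(Oc2ccc(NC(=O)N/N=C/c3ccccc3)cc2F)ccn1` differs from compound 3 by hydrogen in place of nitrooxy on an aromatic carbon. All three measured steps bear on this position and all lie within the scatter, so no change beyond the scatter is expected in this assay for compound 4; the plain phenyl should sit close to compound 3. The step from compound 3 to compound 4 is estimated as a 1.2-fold higher number from compound 3 to compound 4 (0.07 log units; within the scatter). Compound 4 is expected to give 1400 nM, with a range from 700 nM to 2800 nM.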

Compound 4, half-maximal inhibitory concentration: 1860 nM
Estimate against measurement, compound 4: 1.3-fold (0.12 log units) below, within the range that was stated.
By their numbers in this assay, from the lowest: compounds 3, 1, 4 and 2 (each within the scatter of the next).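

Compound 4 carries no substituent on the phenyl, and it still stays level with all three substituted analogues in this assay: a 1.6-fold higher number from compound 3 to compound 4 (0.19 log units; within the scatter), a 1.3-fold higher number from compound 1 to compound 4 (0.12 log units; within the scatter), and a 1.0-fold lower number from compound 2 to compound 4 (0.02 log units; within the scatter). The nitrooxy group, with its 4 heavy atoms, can therefore be replaced by hydrogen without a step beyond the scatter, and the same holds for the 2,6-dichloro and 2,5-dimethoxy patterns when each is compared with plain phenyl. No supporting data are available to explain this flat response.

Still open, as far as these compounds go, is whether an amine or a carboxylic acid on the phenyl, or a longer alkyl chain in place of the aryl group, would give a step beyond the scatter. From the compounds shown here alone, the shared core is constant across all four compounds, so how the numbers respond to changes there also remains unknown.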